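The compounds below may be only part of what the source reports. "The series", "measured", "known", "first", "only" and "open" are said of these compounds alone.

In a functional assay on Raji cells (Homo sapiens) for cytotoxicity, read by CCK-8 assay, with a stated time of 24 h (a higher number here means a weaker inhibitor, a lower number a stronger inhibitor), compound 2 `C=CC(=O)N1C(=O)CC(c2ccc(-c3ccccc3)cc2)Sc2ccccc21` gives 56300 nM and stands alongside compound 1 `C=CC(=O)N1C(=O)CC(c2ccccc2Cl)Sc2ccccc21` at 50400 nM and compound 3 `C=CC(=O)N1C(=O)CC(c2ccccc2C(F)(F)F)Sc2ccccc21` at 50300 nM, all three within the scatter of one another. For the measured compounds named here, the only single-point step among them, a 1.0-fold lower number from compound 1 to compound 3 (0.00 log units; within the scatter), concerns a trifluoromethyl in place of chloro on an aromatic carbon and does not bear directly on the change considered here. Compound 4 `C=CC(=O)N1C(=O)CC(c2ccc(Br)cc2)Sc2ccccc21` differs from compound 2 by bromo in place of phenyl on an aromatic carbon. Going by the values given here, no measured step covers this exchange; what the three numbers show is a flat series. For compound 4 a step of a 1.1-fold lower number from compound 2 to compound 4 (0.03 log units; within the scatter) is therefore expected, none beyond the scatter. In this assay compound 4 is estimated at 52000 nM, with a range from 25000 nM to 110000 nM.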

Compound 4, half-maximal inhibitory concentration: 51300 nM
For compound 4 the middle estimate is 1.0-fold (0.01 log units) above the measured one; the range from low to high includes it.
By their numbers in this assay, from the lowest: compounds 3, 1, 4 and 2 (each within the scatter of the next).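

In this assay, a 1.1-fold lower number from compound 2 to compound 4 (0.04 log units; within the scatter) for bromo in place of phenyl on this aromatic carbon, para to a large group: removing a whole six-membered aromatic ring leaves the number within the scatter. With 4-bromophenyl in place of 2-chlorophenyl on the saturated ring carbon, a 1.0-fold higher number from compound 1 to compound 4 (0.01 log units; within the scatter), so this change also stays within the scatter. Nothing available explains this flatness. Open: whether an amine or a carboxylic acid on this aromatic carbon would move the number beyond the scatter.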